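The source may hold more compounds than are shown below. What is called first, only, known or untested is meant among the compounds shown, and "the series" means these compounds.

Compound 1 `Cn1ncc(Cl)c1-c1cc(C(=O)N[C@@H]2CN[C@H](CCN3CCC(O)CC3)C[C@H]2c2ccc(Cl)c(Cl)c2)oc1Cl` stands highest of the three measured compounds in a functional assay on OVCAR-8 cells (Homo sapiens) for antiproliferative activity; a higher number here means a weaker inhibitor, a lower number a stronger inhibitor: compound 1 gives 15900 nM. Compound 2 `Cn1ncc(Cl)c1-c1cc(C(=O)N[C@@H]2CN[C@H](CCCO)C[C@H]2c2ccc(Cl)c(Cl)c2)oc1Cl` gives 600 nM, and compound 3 `C=CC[C@@H]1C[C@@H](c2ccc(Cl)c(Cl)c2)[C@H](NC(=O)c2cc(-c3c(Cl)cnn3C)c(Cl)o2)CN1` gives 990 nM. The step between them is a 1.7-fold higher number from compound 2 to compound 3 (0.22 log units; within the scatter). Compound 4 `Cn1ncc(Cl)c1-c1cc(C(=O)N[C@@H]2CN[C@H](CC(=O)NC3CC3)C[C@H]2c2ccc(Cl)c(Cl)c2)oc1Cl` has not yet been measured. The change from compound 1 reads (cyclopropylcarbamoyl in place of (4-hydroxypiperidin-1-yl)methyl on a saturated chain carbon bound to a saturated ring carbon). Going by the values given here, two measured steps bear on this change, each taking the same group away from compound 1: a 27-fold lower number from compound 1 to compound 2 (1.42 log units; beyond the scatter) and a 16-fold lower number from compound 1 to compound 3 (1.21 log units; beyond the scatter). In both cases the loss of the (4-hydroxypiperidin-1-yl)methyl group brought a large drop in the number, whether hydroxymethyl or vinyl took its place. Compound 4 also loses that group, and what enters, a cyclopropylcarbamoyl group, is unlike anything in the measured set, so the measured steps say nothing about how this particular replacement behaves at a saturated chain carbon bound to a saturated ring carbon. A large step downward is nonetheless expected, close to the size seen before. Compound 4 is expected to give 1000 nM, with a range from 300 nM to 4000 nM, which would mean a 16-fold lower number from compound 1 to compound 4 (1.20 log units; beyond the scatter).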

Compound 4, half-maximal inhibitory concentration: 580 nM
The estimate for compound 4 lay 1.7-fold (0.24 log units) above the measured number; the measured number falls inside the stated range.
By their numbers in this assay, from the lowest: compounds 4, 2 and 3 (each within the scatter of the next); then compound 1.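

In this assay, the step of a 27-fold lower number from compound 1 to compound 4 (1.44 log units; beyond the scatter) adds a third replacement of the (4-hydroxypiperidin-1-yl)methyl group at this saturated chain carbon bound to a saturated ring carbon, and it shows that the large step also holds for a cyclopropylcarbamoyl group, which brings a three-membered carbon ring and a carbonyl. The other two steps, a 1.7-fold lower number from compound 3 to compound 4 (0.23 log units; within the scatter) and a 1.0-fold lower number from compound 2 to compound 4 (0.01 log units; within the scatter), place compound 4 level with compounds 2 and 3, so the cyclopropylcarbamoyl, vinyl and 2-hydroxyethyl forms cannot be told apart here and compound 1 alone stands apart. Nothing given here accounts for the gap between compound 1 and the other three.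

As far as these compounds go, it remains open whether the high number of compound 1 belongs to the 4-hydroxypiperidine as such or to any amine on this chain, which a plain piperidine, a morpholine or a primary amine at the same place would test. From the compounds shown here alone, it is also open whether the level shared by compounds 2, 3 and 4 would hold for a carboxylic acid or for a longer chain carrying the cyclopropyl amide.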